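The compounds below may be only part of what the source reports. "The series", "measured", "known", "first", "only" and "open" are said of these compounds alone.

Measured so far:
compound 1 `O=C(O)c1cnc2cc(S(=O)(=O)O)ccc2c1O`: 1320000 nM in a functional assay on Ehrlich cells (Mus musculus) for inhibition; on this read-out higher numbers stand for weaker inhibition and lower numbers for stronger inhibition
compound 2 `CC(=O)c1ccc2c(O)c(C(=O)O)cnc2c1`: 794000 nM

Compound 2 stands at the lower of the two numbers shown, but the only comparison available is a 1.7-fold lower number from compound 1 to compound 2 (0.22 log units; within the scatter), which lies within the scatter, so no order between the two is claimed. Compound 3 `NS(=O)(=O)c1ccc2c(O)c(C(=O)O)cnc2c1` differs from compound 2 by sulfamoyl in place of acetyl on an aromatic carbon. For the measured compounds named here, the single measured step bears on this change only loosely, since it exchanged sulfo for acetyl rather than acetyl for sulfamoyl, and it stayed within the scatter. No shift beyond the scatter is therefore expected, with the estimate leaning back toward the number of compound 1. Compound 3 is estimated at 1000000 nM with a range of 300000 nM to 3500000 nM. The expected step is a 1.3-fold higher number from compound 2 to compound 3 (0.10 log units; within the scatter).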

Compound 3, half-maximal inhibitory concentration: 3390000 nM
Beside the measured number, compound 3's estimate is 3.4-fold (0.53 log units) below it, within the range that was stated.
By their numbers in this assay, from the lowest: compounds 2 and 1 (each within the scatter of the next); then compound 3.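

In this assay, for the compounds shown here, this position proves sensitive to the group it carries: sulfamoyl in place of acetyl gives a 4.3-fold higher number from compound 2 to compound 3 (0.63 log units; beyond the scatter), the first step to clear the scatter. The sulfur substituent matters too, since amino in place of hydroxy on the sulfonyl sulfur gives a 2.6-fold higher number from compound 1 to compound 3 (0.41 log units; beyond the scatter), which sets compound 3 apart from both earlier compounds. No available data explain either shift.

Still open, on these data alone, is whether an amine, a carboxylic acid or a longer alkyl chain at this position would give a number clearly lower than that of compound 2. Substituted sulfonamides, which would test the amino hydrogens of the sulfamoyl group, are also open.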